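The source may report more compounds than this note shows. Statements on the series, on what has been measured and on what is new or still open speak of the compounds shown alone.

Compound 1, `COc1cc(CN(C(=O)Nc2ccc(C#N)cc2)n2cnnc2)cc(OC)c1OC`: 20600 nM in a functional assay on DU-145 cells (Homo sapiens) for cytotoxicity, read by MTT assay, with a stated time of 48 h; on this read-out lower numbers stand for stronger inhibition and higher numbers for weaker inhibition.
Compound 2, `CCCCCCCCCNC(=O)N(Cc1cc(OC)ccc1OC)n1cnnc1`: > 50000 nM in this assay.

For the measured compounds named here, only two compounds have been measured in this assay. Going by the values given here, compound 1 stands as the sole compound with an actual number there, giving 20600 nM. Compound 2 gives > 50000 nM, which is a limit of the assay and not a number, in line with the limit of > 50000 nM in this assay, at which 1 of the 2 values shown sits. Among the compounds with values here, the two share a common core but differ in several places at once, so no single step joins them; all they show together is that compound 1 has a number where compound 2 does not.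

Compound 3, `COc1cc(CN(C(=O)Nc2ccc(C)cc2)n2cnnc2)cc(OC)c1OC`, is not yet measured. It differs from compound 1 in one place: methyl in place of cyano on an aromatic carbon. Within the data shown here, no measured step of this kind exists to gauge the change. Starting from compound 1, the expected step is a 1.5-fold higher number from compound 1 to compound 3 (0.16 log units; within the scatter), leaning toward weaker inhibition but hardly beyond the scatter. Compound 3 is therefore estimated at 30000 nM, within a range from 10000 nM to 100000 nM.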

Compound 3, half-maximal inhibitory concentration: 20800 nM
Compound 3: middle estimate off by 1.4-fold (0.16 log units), on the high side; the range from low to high includes it.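

For the compounds shown here, the step of a 1.0-fold higher number from compound 1 to compound 3 (0.00 log units; within the scatter) is the first measured change at a single place in this assay and concerns methyl in place of cyano on an aromatic carbon, para to a large group. It shows that, on the core of compound 1, 4-cyanophenyl and 4-methylphenyl cannot be told apart in this read-out, so the number here does not depend on which of these two groups is present. Compound 2 remains a limit of the assay and not a number: the limit of > 50000 nM in this assay, at which 1 of the 3 values shown sits.

As far as these compounds go, whether any group at this place can move the number beyond the scatter stays open, for instance an amine, a carboxylic acid or a longer chain such as butyl. From the compounds shown here alone, it is also open whether methyl and cyano would stay equivalent on a different core.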